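The compounds below may be only part of what the source reports. "The series", "measured", "known", "first", "only" and "open" are said of these compounds alone.

Compound 1, `CC(C)CSc1nc(N)nc2c1ncn2/C=C1/CC1(CO)CO`: in an ADME assay on HFF cells (Homo sapiens) for cytotoxicity, with a stated time of 8 days (on this read-out higher numbers stand for lower toxicity in this test and lower numbers for higher toxicity in this test), compound 1 gives > 300000 nM, which is a limit of the assay.
Compound 2, `CCCOc1nc(N)nc2c1ncn2/C=C1/CC1(CO)CO`: in this assay compound 2 gives > 300000 nM, again a limit of the assay.
Compound 3, `CCCCCOc1nc(N)nc2c1ncn2/C=C1/CC1(CO)CO`: in this assay compound 3 gives 259000 nM.

Among the compounds with values here, compound 3 therefore stands as the only number among the three; the other two values are limits, as the limit of > 300000 nM in this assay, at which 2 of the 3 values shown sit, sets out, and so its place relative to them is only loosely fixed. Compound 4, `CCCCCCSc1nc(N)nc2c1ncn2/C=C1/CC1(CO)CO`, has not yet been measured in this assay; its change from compound 3 is hexylsulfanyl in place of pentyloxy on an aromatic carbon.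

Within the data shown here, two measured steps bear on this change. The first is an at least 1.1-fold lower number from compound 1 to compound 3 (0.06 log units; that floor lies within the scatter), which swaps a sulfanyl chain for an alkoxy chain, the reverse of the present direction. The second is an at least 1.1-fold lower number from compound 2 to compound 3 (0.06 log units; that floor lies within the scatter), which lengthens the chain. Both are floors lying within the scatter. The step that the two limits leave unreadable from compound 1 to compound 2 adds nothing readable. Among the measured compounds shown here, no step here reaches beyond the scatter, so for compound 4 no change beyond the scatter is expected in this assay; the estimated step is a 1.2-fold higher number from compound 3 to compound 4 (0.06 log units; within the scatter). Compound 4 is thus expected to give about 300000 nM, between 150000 nM and 600000 nM, with a fair chance that only a limit is reported.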

Compound 4, half-maximal cytotoxic concentration: > 300000 nM
Compound 4: no number, only a limit; the forecaster's own chance of this, stated with the estimate: 50%; the middle value lies on the limit itself.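

In this assay, hexylsulfanyl in place of pentyloxy on this aromatic carbon gives an at least 1.1-fold higher number from compound 3 to compound 4 (0.06 log units; that floor lies within the scatter), so the exchange of the oxygen-linked chain for the sulfur-linked chain shows no change that can be told from ordinary repeat variation. Compound 4 gives > 300000 nM, which is a limit of the assay, so the hexylsulfanyl chain shows no measurable cytotoxic concentration in the tested range, just as the shorter isobutylsulfanyl chain did in compound 1. The steps to compound 4 from compound 1 and from compound 2 cannot be read, because both ends of each step are limits: the limit of > 300000 nM in this assay, at which 3 of the 4 values shown sit.

Within the data shown here, with compound 3 as the only compound that gives an actual number, the true gap between the pentyloxy and hexylsulfanyl chains stays unknown, and so does any real effect of chain length or of the linking atom. Going by these compounds, it also remains open whether a longer chain such as octylsulfanyl, or an amine or a carboxylic acid in place of these chains on the same carbon, would bring the number clearly down in this assay.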